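Isopropyl to Isobutyl: Expecting Little Change

The source may hold more compounds than are shown below. What is called first, only, known or untested is meant among the compounds shown, and "the series" means these compounds.

Among the compounds with values here, compound 1 `CC(C)[C@H](NC(=O)CN(c1nc(Cl)nc2[nH]cnc12)C1CC1)C(=O)OCc1ccccc1` was tested in a functional assay on the whole organism (Tail, strain ICR) with Mus musculus as the target, in the tail flick test, with a stated time of 90 min, at a dose of 25 umol/kg by the oral route (a higher number here means a stronger effect of the compound at the dose given, a lower number a weaker effect), where compound 1 gives 51.3%, the highest of the three numbers measured so far. Compound 2 `O=C(CN(c1ncnc2c1ncn2C1CCCCO1)C1CC1)N[C@@H](CO)C(=O)OCc1ccccc1` gives 32.2% and compound 3 `CC(C)[C@H](NC(=O)CN(c1nc(Cl)nc2[nH]cnc12)C1CC1)C(=O)O` gives 30.3%, both lower than compound 1 by more than the scatter. Within the data shown here, the only step between measured compounds that differ in a single place is the one in which hydrogen replaces benzyl on an oxygen next to a carbonyl group, and there the number falls by a number 21 percentage points lower from compound 1 to compound 3 (beyond the scatter).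

Compound 4 `CC(C)C[C@H](NC(=O)CN(c1nc(Cl)nc2[nH]cnc12)C1CC1)C(=O)OCc1ccccc1` differs from compound 1 at a different place: isobutyl in place of isopropyl on a saturated chain carbon bound to an amide-type nitrogen and a carbonyl carbon. Among the measured compounds shown here, no measured step touches this place, and compound 2 differs from compound 1 in several places at once, so its value says nothing about this change on its own. With nothing bearing on the change, the expectation is that the read-out stays close to where compound 1 stands. Compound 4 is therefore estimated to give 48%, with a range from 30% to 65%. That estimate means an expected step of a number 3.3 percentage points lower from compound 1 to compound 4 (within the scatter), within the scatter.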

Compound 4, a percentage reported as activity, at one dose (the size of the read-out at that dose, not a potency): 15.2%
The estimate for compound 4 lay 32.8 percentage points above the measured number, outside the stated range (below it).
By their numbers in this assay, from the lowest: compound 4; then compounds 3 and 2 (each within the scatter of the next); then compound 1.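

In this assay, the change to isobutyl in place of isopropyl gives a number 36.1 percentage points lower from compound 1 to compound 4 (beyond the scatter), so this position on a saturated chain carbon bound to an amide-type nitrogen and a carbonyl carbon is sensitive to even a small change in the chain. Within the data shown here, the earlier single-place step concerned only the benzyl on the oxygen, so this is the first sign that the group on this carbon also matters to the read-out at this dose. Nothing at hand explains why the read-out responds to this change.

From the compounds shown here alone, it remains open whether a smaller group such as methyl, a longer chain or an amine at this carbon would keep or lose the effect. It is also unknown whether isobutyl would give a similar step in the free acid, compound 3.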